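Methoxy in Place of Hydrogen on the Outer Phenyl

The compounds below may be only part of what the source reports. "The series", "measured", "known", "first", "only" and "open" are said of these compounds alone.

Compound 1 `O=C1NC2(CC2c2ccc3cccc(OCc4ccccc4)c3n2)C(=O)N1c1ccc([N+](=O)[O-])cc1` gives 300 mg/kg in a functional assay on the whole organism (strain Kunming) with Mus musculus as the target, in the maximal electroshock model, with a stated time of 4 h; on this read-out higher numbers stand for an effect only at larger amounts of compound and lower numbers for an effect already at smaller amounts
Compound 2 `O=C1NC2(CC2c2ccc3cccc(OCc4ccccc4)c3n2)C(=O)N1c1ccc(Br)cc1` gives 300 mg/kg in this assay
Compound 3 `O=C1NC2(CC2c2ccc3cccc(OCc4ccccc4)c3n2)C(=O)N1c1ccccc1` gives 300 mg/kg in this assay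

The three measured compounds share one core and differ only in the group carried on the outer phenyl. Going by the values given here, on the numbers so far compound 3 stands level with compounds 1 and 2 in this assay: no change at the digits printed from compound 1 to compound 3 (within the scatter) and no change at the digits printed from compound 2 to compound 3 (within the scatter), and between the other two no change at the digits printed from compound 1 to compound 2 (within the scatter). Compound 4 `COc1ccc(N2C(=O)NC3(CC3c3ccc4cccc(OCc5ccccc5)c4n3)C2=O)cc1` differs from compound 3 by methoxy in place of hydrogen on an aromatic carbon. All three measured steps bear on this change; each also exchanges one group on an aromatic carbon of that phenyl, and none of them moved the read-out beyond the scatter. A further exchange of the same kind is therefore expected to leave the read-out essentially where it is, so that no change at the digits printed from compound 3 to compound 4 (within the scatter) is the expected size of the step. Compound 4 is accordingly estimated at 300 mg/kg in this assay, with a range from 150 mg/kg to 600 mg/kg.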

Compound 4, minimum effective dose: 100 mg/kg
Compound 4: the middle estimate sits 3.0-fold (0.48 log units) above what was measured, outside the stated range (below it).
By their numbers in this assay, from the lowest: compound 4; then compounds 1, 2 and 3 (each within the scatter of the next).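

Going by these compounds alone, the outer phenyl is not indifferent to what it carries: hydrogen, bromo and nitro read alike, but methoxy, on an aromatic carbon para to a large group, is the first exchange to move the read-out beyond the scatter in this assay (a 3.0-fold lower number from compound 3 to compound 4 (0.48 log units; beyond the scatter)). The same shift appears against the other two groups (a 3.0-fold lower number from compound 2 to compound 4 (0.48 log units; beyond the scatter); a 3.0-fold lower number from compound 1 to compound 4 (0.48 log units; beyond the scatter)), so compound 4 takes effect at a smaller amount than any of the other three. Nothing at hand explains why methoxy alone makes this difference.

The compounds shown leave open whether ethoxy, hydroxy or an amine on the same carbon would lower the number further or leave it level with compound 3. They also leave open whether methoxy elsewhere on this phenyl would give the same shift.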